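The source may hold more compounds than are shown below. What is called first, only, known or untested is meant among the compounds shown, and "the series" means these compounds.

Among the compounds with values here, compound 1 `CCc1nc2c(-c3ccc(Cl)cc3Cl)ccnc2n1[C@@H](CC)C1CC1` gives the lowest of the three numbers so far in an assay for binding affinity to Corticotropin releasing factor receptor (Rattus norvegicus) (a higher number here means a weaker inhibitor, a lower number a stronger inhibitor), at 0.4 nM. Compound 2 `CCCC(C)n1c(CC)nc2c(-c3ccc(OC)cc3C(F)(F)F)ccnc21` gives 0.74 nM in this assay, a gap within the scatter of compound 1, while compound 3 `CCCC(C)n1c(CC)nc2c(-c3ccc(C(C)OC)cc3Cl)ccnc21` gives 3.5 nM, a gap beyond it. Compounds 2 and 3 both carry a 1-methylbutyl on the aromatic nitrogen and also differ from compound 1 in the aryl group. Compound 4 `CCCC(C)n1c(CC)nc2c(-c3ccc(Cl)cc3Cl)ccnc21` keeps the aryl group of compound 1 and changes only the group on the ring nitrogen: 1-methylbutyl in place of 1-cyclopropylpropyl on an aromatic nitrogen. Within the data shown here, no measured pair isolates this change. Because compound 2 with its 1-methylbutyl gives 0.74 nM, a step no larger than the scatter is expected a 1.5-fold higher number from compound 1 to compound 4 (0.18 log units; within the scatter). Compound 4 is estimated at 0.6 nM, between 0.2 nM and 2 nM.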

Compound 4, inhibition constant: 0.5 nM
Estimate against measurement, compound 4: 1.2-fold (0.08 log units) above; low and high end bracket the measured number.
By their numbers in this assay, from the lowest: compounds 1, 4 and 2 (each within the scatter of the next); then compound 3.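

In this assay, 1-methylbutyl on the aromatic nitrogen matches 1-cyclopropylpropyl when the aryl group is held constant, with a 1.3-fold higher number from compound 1 to compound 4 (0.10 log units; within the scatter); losing the three-membered ring and the defined stereocentre leaves the number within the scatter. The aryl group matters more here: chloro in place of 1-methoxyethyl on an aromatic carbon gives a 7.0-fold lower number from compound 3 to compound 4 (0.85 log units; beyond the scatter). Nothing measured here explains either step. The compounds shown leave open whether a longer chain or an amine on that nitrogen would be tolerated, and whether the match between the two nitrogen groups holds with other aryl groups.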